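A few compounds are considered here, and "the series" means these few. Any claim that something is new, unique, unknown or untested is made for them only; others in the source may bear on it.

Measured in a functional assay on MCF7 cells (Homo sapiens) for inhibition, read by sulforhodamine B assay, with a stated time of 48 h; a lower number here means a stronger inhibitor, a higher number a weaker inhibitor:
- compound 1 `COc1ccc(C(c2ccc(OC(C)CN(C)C)cc2)c2cccc3ccccc23)c(OC)c1OC`: 13100 nM
- compound 2 `COc1ccc(C(O)(Cc2ccc(C)cc2)c2cccc3ccccc23)c(OC)c1OC`: > 20000 nM

Compound 2 has no exact number in this assay, since its > 20000 nM is a limit of the assay. Compound 3 `COc1ccc(C(O)(Cc2ccc(F)cc2)c2cccc3ccccc23)c(OC)c1OC` differs from compound 2 by fluoro in place of methyl on an aromatic carbon, with fluoro in place of methyl on an aromatic carbon, para to a large group. For the measured compounds named here, no measured pair shows this change, so no step beyond the scatter is expected, and compound 3 may also reach the limit. The expected change is an at least 1.1-fold lower number from compound 2 to compound 3 (0.04 log units; that floor lies within the scatter). Compound 3 is estimated at 18000 nM, within an expected range of 8000 nM to 30000 nM.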

Compound 3, half-maximal inhibitory concentration: 7560 nM
The estimate for compound 3 lay 2.4-fold (0.38 log units) above the measured number, outside the stated range (below it).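

In this assay, for the compounds shown here, this is the first reading at this position: on the aromatic carbon para to a large group, fluoro in place of methyl gives an at least 2.6-fold lower number from compound 2 to compound 3 (0.42 log units; beyond the scatter). With this change, compound 3 gives a measurable value of 7560 nM. The step is only a floor, set by the limit on compound 2: the limit of > 20000 nM in this assay, at which 1 of the 3 values shown sits.

As far as these compounds go, whether chloro, methoxy or a plain hydrogen at this position would read like fluoro stays open. The true size of the step also stays open, and the compounds shown do not tell why it occurs.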